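Cytotoxicity notes on a small aminothiazole-free series of two measured compounds

This account rests on a few compounds, and the source may have more. Where it says the series, first, only, none or still open, it means among the compounds named here.

Measured so far:
Compound 1, `CC(C)OCCCNC(=O)c1csc(Nc2ccc(Cl)c(Cl)c2)n1`, in an ADME assay on MDCK cells (Canis lupus familiaris) for cytotoxicity, with a stated time of 48 h (a higher number here means that more compound is tolerated, a lower number that less compound is tolerated), compound 1 gives 100000 nM.
Compound 2, `CCOCCCNC(=O)c1csc(Nc2ccc(Cl)c(Cl)c2)n1`, in this assay compound 2 gives > 100000 nM, which is a limit of the assay and not a number.

Compound 2 stands at the top of what this assay can report: its value is a limit, so its true tolerance is open. Among the measured compounds shown here, the only measured step, a number no lower from compound 1 to compound 2 (the limit leaves the size open), has a size that cannot be read, due to the limit of > 100000 nM in this assay, at which 1 of the 2 values shown sits.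

Compound 3, `CCOCCCNC(=O)c1csc(Nc2ccc(Cl)c(C)c2)n1`, differs from compound 2 by methyl in place of chloro on an aromatic carbon. The measured step concerns the chain and not the aromatic ring, so it offers no direct guidance on this change. With both measured compounds tolerated at or near the ceiling of this assay, compound 3 is expected to remain there, with an estimated 100000 nM spanning 50000 nM to 200000 nM. This amounts to an expected step of a number no higher from compound 2 to compound 3 (the limit leaves the size open), most likely reported again only as a limit.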

Compound 3, half-maximal cytotoxic concentration: 52000 nM
Compound 3: the middle estimate sits 1.9-fold (0.28 log units) above what was measured; low and high end bracket the measured number.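

The change from chloro to methyl, on the carbon ortho to a chloro group and meta to a large group, is the first change on the aromatic ring among these compounds, and in this assay it gives an at least 1.9-fold lower number from compound 2 to compound 3 (0.28 log units; that floor lies within the scatter). From the compounds shown here alone, the true size of this step stays open because the value of compound 2 is only a limit: the limit of > 100000 nM in this assay, at which 1 of the 3 values shown sits. Among the compounds shown here, compound 3 nonetheless carries a number and not a limit, so this is the first single change here with a readable lower bound on its size, even though that bound does not clear the scatter.

Going by these compounds, how a fluoro, a methoxy or a trifluoromethyl group would read on this carbon remains open. Equally open, on these data alone, is whether the same change would give a similar step on the chain of compound 1.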